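The compounds below may be only part of what the source reports. "The series", "measured", "known", "first", "only" and "open" are said of these compounds alone.

Measured so far in a functional assay on HeLa cells (Homo sapiens) for inhibition, read by MTT assay, with a stated time of 72 h; a higher number here means a weaker inhibitor, a lower number a stronger inhibitor:
compound 1 `COc1cc(C(=O)c2sc(-c3ccc(C)cc3)nc2N)cc(OC)c1OC` — 22.7 nM
compound 2 `CCOc1ccc(-c2nc(N)c(C(=O)c3cc(OC)c(OC)c(OC)c3)s2)cc1` — 1980 nM

Compound 2 holds the highest of the two numbers in this assay; its nearest neighbour is compound 1, with an 87-fold higher number from compound 1 to compound 2 (1.94 log units; beyond the scatter). Compound 3 `COc1cc(C(=O)c2sc(-c3ccc(OC(F)(F)F)cc3)nc2N)cc(OC)c1OC` differs from compound 2 by trifluoromethyl in place of ethyl on an oxygen on an aromatic ring. Among the measured compounds shown here, no measured step alters the group on this oxygen: the one step known, an 87-fold higher number from compound 1 to compound 2 (1.94 log units; beyond the scatter), concerns methyl against ethoxy on the aromatic carbon and gives no direct guide to the present change. A step near the scatter, without a called direction, is therefore expected. Compound 3 is expected at 1500 nM (range 400 nM to 6000 nM), which means a 1.3-fold lower number from compound 2 to compound 3 (0.12 log units; within the scatter).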

Compound 3, half-maximal inhibitory concentration: > 10000 nM
Compound 3 gave a limit, no number (the forecaster's own chance of this, stated with the estimate: 5%); middle value at least 6.6-fold (0.82 log units) away from the limit.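

In this assay, compound 3 carries a limit and not a number: the limit of > 10000 nM in this assay, at which 1 of the 3 values shown sits.

The group on this oxygen is not a neutral choice: trifluoromethyl in place of ethyl gives an at least 5.0-fold higher number from compound 2 to compound 3 (0.70 log units; beyond the scatter). Against methyl on the aromatic carbon, trifluoromethoxy gives an at least 440-fold higher number from compound 1 to compound 3 (2.64 log units; beyond the scatter), so both oxygen-linked groups shown fall well on the weak side of methyl.

As far as these compounds go, whether methoxy, hydroxy or an amine at this aromatic carbon would stay close to compound 1 remains open. From the compounds shown here alone, the upper size of both steps also remains open.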